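Bromo for Chloro: What to Expect of Compound 4

This account rests on a few compounds, and the source may have more. Where it says the series, first, only, none or still open, it means among the compounds named here.

Three compounds have been measured in a functional assay on B16-F10 cells (Mus musculus) for antiproliferative activity, read by ELISA and MTT assay, with a stated time of 48 h; a higher number here means a weaker inhibitor, a lower number a stronger inhibitor:
compound 1 `O=C(/C=C/c1ccccc1)NS(=O)(=O)c1ccc(Cl)cc1`: 2.2 ug/mL
compound 2 `O=C(/C=C/c1ccccc1)NS(=O)(=O)c1ccc(Br)cc1`: 3.9 ug/mL
compound 3 `O=C(/C=C/c1ccc(Cl)cc1)NS(=O)(=O)c1ccc(Cl)cc1`: 2.5 ug/mL

Compound 2 differs from compound 1 by bromo in place of chloro on an aromatic carbon, and this change gave a 1.8-fold higher number from compound 1 to compound 2 (0.25 log units; within the scatter). Compound 3 differs from compound 1 by chloro in place of hydrogen on an aromatic carbon, and compound 3 and compound 1 give values within the scatter of each other. Compound 4 `O=C(/C=C/c1ccc(Cl)cc1)NS(=O)(=O)c1ccc(Br)cc1` has not yet been measured; it differs from compound 3 by bromo in place of chloro on an aromatic carbon. The place of the change is described in the same words as for compound 1 to compound 2, so it is the same change, made on a different core. That earlier change gave a 1.8-fold higher number from compound 1 to compound 2 (0.25 log units; within the scatter), and this rests on that single earlier pair alone. The step from compound 3 to compound 4 is therefore expected to resemble that earlier step. Compound 4 is thus expected to give 3.8 ug/mL in this assay, a step of a 1.5-fold higher number from compound 3 to compound 4 (0.18 log units; within the scatter). The estimate for compound 4 is expected to fall between 2 ug/mL and 7.5 ug/mL.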

Compound 4, half-maximal inhibitory concentration: 2.8 ug/mL
For compound 4 the middle estimate is 1.4-fold (0.13 log units) above the measured one, and the stated range covers the measured number.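

In this assay, bromo in place of chloro on the core of compound 3 gave a 1.1-fold higher number from compound 3 to compound 4 (0.05 log units; within the scatter), and the two cores take this change alike: the same change on two cores in this assay, a 1.8-fold higher number (0.25 log units; within the scatter) from compound 1 to compound 2 and a 1.1-fold higher number (0.05 log units; within the scatter) from compound 3 to compound 4, 1.6-fold (0.20 log units) apart, within the scatter of two such steps. Chloro in place of hydrogen on an aromatic carbon gave a 1.4-fold lower number from compound 2 to compound 4 (0.14 log units; within the scatter), and this change also reads alike on both cores: the same change on two cores in this assay, a 1.1-fold higher number (0.06 log units; within the scatter) from compound 1 to compound 3 and a 1.4-fold lower number (0.14 log units; within the scatter) from compound 2 to compound 4, 1.6-fold (0.20 log units) apart, within the scatter of two such steps. Among the compounds shown here, every one of these steps lies within the scatter, so the four compounds show only that neither change made a clear difference on either core, not that a change with a real effect would carry over from one core to another. On these data alone, it remains open whether a different group at the same place, such as an amine or a carboxylic acid, would give a step beyond the scatter, and whether that step would then hold on both cores.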